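Swapping a chloro for an amino on a purine core

The source may report more compounds than this note shows. Statements on the series, on what has been measured and on what is new or still open speak of the compounds shown alone.

Compound 1 `ClCc1ccccc1Cn1cnc2c(Cl)nc(Cl)nc21` and compound 2 `ClCc1ccccc1Cn1cnc2ncnc(Cl)c21` share the same core and the same chloromethyl-bearing benzyl chain, and differ only in what sits on the six-membered ring. In a functional assay on MDA-MB-435 cells (Homo sapiens) for cytotoxicity, read by sulforhodamine B assay, with a stated time of 48 h (on this read-out higher numbers stand for lower toxicity in this test and lower numbers for higher toxicity in this test), compound 1 gives 6450 nM, while compound 2 gives 7580 nM. Compound 1 has the lower of the two numbers, but the gap to compound 2 lies within the usual scatter of such measurements, so the two cannot be told apart.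

Compound 3 `Nc1nc(Cl)c2ncn(Cc3ccccc3CCl)c2n1` has not yet been measured in this assay. It differs from compound 1 in one place: amino in place of chloro on an aromatic carbon. Among the measured compounds shown here, no measured pair shows this exact swap, so the expected step rests on the two values at hand. Because compound 2 gives 7580 nM with nothing at all at this position and still lands close to compound 1, the position seems tolerant, and the step from compound 1 to compound 3 is expected to be small, a 1.2-fold higher number from compound 1 to compound 3 (0.09 log units; within the scatter), in no clear direction beyond the scatter. Compound 3 is estimated at 8000 nM, within a range from 3000 nM to 20000 nM.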

Compound 3, concentration lethal to 50% of the cells: > 100000 nM
Compound 3: a limit, no number; the forecaster's own chance of this, stated with the estimate: 10%; at least 12-fold (1.09 log units) between middle value and limit.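

In this assay, putting an amino group where compound 1 carries a chloro, on the aromatic carbon between two ring nitrogen atoms, gives an at least 15-fold higher number from compound 1 to compound 3 (1.19 log units; beyond the scatter). Compounds 1 and 2 lie within the scatter of each other and gave no hint that this carbon matters, whereas this single exchange separates two compounds clearly, so toxicity in this test does depend on which group sits here. The figure for compound 3 is a limit of the assay and not a number: the limit of > 100000 nM in this assay, at which 1 of the 3 values shown sits.

With amino as the only replacement for chloro at this carbon, the compounds shown cannot tell whether the large step belongs to the amino group itself or would follow from other groups placed here as well. A methoxy group or a dimethylamino group on this carbon would help to settle that, and the same exchange on the other chloro of the shared core remains an open question too.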